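From Cyclopentyl to 3-Chlorophenyl on a Urea Nitrogen

A few compounds are considered here, and "the series" means these few. Any claim that something is new, unique, unknown or untested is made for them only; others in the source may bear on it.

Of the compounds shown here, two with a shared core have so far been measured in a functional assay on HepG2 cells (Homo sapiens) for antiproliferative activity, read by MTT assay, with a stated time of 48 h; on this read-out lower numbers stand for stronger inhibition and higher numbers for weaker inhibition. Compound 1 `O=C(Nc1cccc(CNc2nccnc2Cl)c1)NC1CCCC1` carries a cyclopentyl group on one amide-type nitrogen, and in this assay compound 1 gives 18400 nM. Compound 2 `O=C(Nc1ccc(C(F)(F)F)cc1)Nc1cccc(CNc2nccnc2Cl)c1` carries a six-membered aromatic ring of carbon only in that position, and in this assay compound 2 gives 5050 nM. Of these two numbers, compound 1 has the higher one, and its gap to compound 2 lies beyond the usual scatter, so compound 1 is the weaker inhibitor of the pair.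

Compound 3 `O=C(Nc1cccc(Cl)c1)Nc1cccc(CNc2nccnc2Cl)c1` has not yet been measured. It differs from compound 1 in a single place: 3-chlorophenyl in place of cyclopentyl on an amide-type nitrogen. Within the data shown here, compound 2 offers the only guide, because its aromatic ring on the same nitrogen goes with the lower number 5050 nM. On that basis a downward step of moderate size is expected, a 3.1-fold lower number from compound 1 to compound 3 (0.49 log units; beyond the scatter). For compound 3 the expected value in this assay is 6000 nM, within a range from 2500 nM to 15000 nM.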

Compound 3, half-maximal inhibitory concentration: 9140 nM
The estimate for compound 3 lay 1.5-fold (0.18 log units) below the measured number, within the range that was stated.
By their numbers in this assay, from the lowest: compounds 2, 3 and 1 (each within the scatter of the next, the first and the last beyond it).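

In this assay the exchange of cyclopentyl for 3-chlorophenyl on this amide-type nitrogen gives a 2.0-fold lower number from compound 1 to compound 3 (0.30 log units; within the scatter) and so does not separate the two compounds beyond the usual scatter. The earlier pair could not show this: compound 2 alone suggested that an aromatic ring of carbon only on this nitrogen goes with a clear difference from compound 1, whereas compound 3 shows that such a ring does not bring a clear difference in every case. Compound 3 also lies within the scatter of compound 2, so the two aromatic groups on this nitrogen cannot be told apart here, although only compound 2 stands clearly apart from compound 1.

The compounds shown leave open how an unsubstituted phenyl group would compare on this nitrogen, and whether a phenyl ring carrying an amine or a carboxylic acid would stand apart from compound 3. They also leave open whether a longer alkyl chain or a morpholine ring in place of cyclopentyl would differ from compound 1 by more than the scatter. Nothing available here accounts for these numbers.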